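This account rests on a few compounds, and the source may have more. Where it says the series, first, only, none or still open, it means among the compounds named here.

Compound 1 `Fc1ccccc1N1CCN(Cn2nc(-c3ccc4c(c3)OCCO4)oc2=S)CC1` carries a 2-fluorophenyl on an amine nitrogen in a ring that hangs from the shared core. In a functional assay on BGC-823 cells (Homo sapiens) for antiproliferative activity, read by MTT assay, with a stated time of 48 h (on this read-out lower numbers stand for stronger inhibition and higher numbers for weaker inhibition), compound 1 gives > 50000 nM, which is a limit of the assay and not a measured number. Compound 2 `COc1ccc(N2CCN(Cn3nc(-c4ccc5c(c4)OCCO5)oc3=S)CC2)cc1` carries a 4-methoxyphenyl in that position, and in this assay compound 2 gives 18900 nM. Compound 3 `Fc1ccc(N2CCN(Cn3nc(-c4ccc5c(c4)OCCO5)oc3=S)CC2)cc1` carries a 4-fluorophenyl instead. In this assay compound 3 gives > 50000 nM, again only a limit. Between the measured compounds the picture is an at least 2.6-fold lower number from compound 1 to compound 2 (0.42 log units; beyond the scatter), a step that the two limits leave unreadable from compound 1 to compound 3 and an at least 2.6-fold higher number from compound 2 to compound 3 (0.42 log units; beyond the scatter). Compound 1 therefore stands at the limit of > 50000 nM in this assay, at which 2 of the 3 values shown sit, with no exact number of its own.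

Compound 4 `S=c1oc(-c2ccc3c(c2)OCCO3)nn1CN1CCN(c2ccccc2)CC1` differs from compound 1 by hydrogen in place of fluoro on an aromatic carbon. Among the compounds with values here, none of the measured steps removes the fluoro outright: a step that the two limits leave unreadable from compound 1 to compound 3 moves it to another carbon and cannot be read, while an at least 2.6-fold lower number from compound 1 to compound 2 (0.42 log units; beyond the scatter) brings in a different group altogether. Nothing here points to a strong gain, so compound 4 is expected to stay close to where compound 1 sits, with a real chance that only a limit is reported. The expected step is an at least 1.1-fold lower number from compound 1 to compound 4 (0.04 log units; that floor lies within the scatter). Compound 4 is estimated at 45000 nM, within 15000 nM to 150000 nM.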

Compound 4, half-maximal inhibitory concentration: > 50000 nM
Compound 4 ended at the assay's limit; the forecaster's own chance of this, stated with the estimate: 55%; middle value at least 1.1-fold (0.04 log units) away from the limit.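

Taking the fluoro away altogether does not lift the compound off the limit: in this assay compound 4 gives > 50000 nM, which is a limit of the assay and not a measured number. Hydrogen in place of methoxy comes out as an at least 2.6-fold higher number from compound 2 to compound 4 (0.42 log units; beyond the scatter), so the 4-methoxyphenyl now stands apart from the plain phenyl as well as from a fluorinated ring, while the steps among compound 1, compound 3 and compound 4 cannot be read, as each joins two limits. A fluoro on the ring is therefore not needed for a compound to stay inactive at the top of the tested range, and compound 2 remains the only one with an exact number: the limit of > 50000 nM in this assay, at which 3 of the 4 values shown sit.

On these data alone, how far past the limit compound 1, compound 3 and compound 4 really lie stays unknown, so any effect of the fluoro, at either place on the ring, remains hidden. The compounds shown also leave open whether the gain belongs to the methoxy itself or would also appear with an ethoxy, a hydroxyl or an amine in its place.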